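Amide Aryl Exchange and Antiproliferative Potency

The compounds below may be only part of what the source reports. "The series", "measured", "known", "first", "only" and "open" are said of these compounds alone.

Compound 1 `COc1cc(C(=O)Nc2ccc(C(=O)/C=C/c3nc(C)c(C)nc3C)cc2)cc(OC)c1OC`: 4740 nM
Compound 2 `Cc1nc(C)c(/C=C/C(=O)c2ccc(NC(=O)c3ccccc3F)cc2)nc1C`: 1980 nM

In a functional assay on MDA-MB-231 cells (Homo sapiens) for antiproliferative activity, read by CCK-8 assay, with a stated time of 72 h (a lower number here means a stronger inhibitor, a higher number a weaker inhibitor), compound 2 holds the lower of the two numbers, and compound 1 sits a step higher, beyond the scatter. Compound 3 `COc1ccc(C(=O)Nc2ccc(C(=O)/C=C/c3nc(C)c(C)nc3C)cc2)cc1OC` alters the amide: 3,4-dimethoxyphenyl in place of 2-fluorophenyl on a carbonyl carbon. Compound 3 is expected to move back toward the weaker side, because compound 1 gives 4740 nM and is the closer relative in this part. The step from compound 2 to compound 3 is estimated as a 1.8-fold higher number from compound 2 to compound 3 (0.25 log units; within the scatter), a rise of modest size. Compound 3 is estimated at 3500 nM, with a range from 1500 nM to 8000 nM.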

Compound 3, half-maximal inhibitory concentration: 3360 nM
Compound 3: the middle estimate sits 1.0-fold (0.02 log units) above what was measured; low and high end bracket the measured number.
By their numbers in this assay, from the lowest: compounds 2, 3 and 1 (each within the scatter of the next, the first and the last beyond it).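

In this assay, 3,4-dimethoxyphenyl in place of 2-fluorophenyl on a carbonyl carbon gives a 1.7-fold higher number from compound 2 to compound 3 (0.23 log units; within the scatter), so this exchange at the amide cannot be told apart from the scatter. Hydrogen in place of methoxy on an aromatic carbon gives a 1.4-fold lower number from compound 1 to compound 3 (0.15 log units; within the scatter), also within the scatter. Neither single change therefore separates compound 3 from its neighbour. Nothing available here explains these numbers.

From the compounds shown here alone, whether an amine or a carboxylic acid on that aromatic ring would move the number beyond the scatter stays open.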